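Pentyl to cyclopropylmethyl: a small change in tolerated concentration?

The compounds below may be only part of what the source reports. "The series", "measured", "known", "first", "only" and "open" are said of these compounds alone.

Compound 1 `CCCCCO[C@@H]1C=CC(=O)[C@@H](COC(=O)C(C)(C)C)O1` gives 7380 nM
Compound 2 `CC(=O)OC[C@H]1O[C@H](OCCC(C)C)C=CC1=O` gives 19800 nM

In an ADME assay on Vero cells (Chlorocebus sabaeus) for cytotoxicity, read by resazurin assay, with a stated time of 24 h (a higher number here means that more compound is tolerated, a lower number that less compound is tolerated), compound 1 has the lower of the two numbers, and its gap to compound 2 lies beyond the scatter. Of this pair, compound 1 is therefore the less tolerated. Compound 3 `CC(C)(C)C(=O)OC[C@H]1O[C@H](OCC2CC2)C=CC1=O` is still unmeasured. Its difference from compound 1 is cyclopropyl in place of butyl on a saturated chain carbon bound to an oxygen on a saturated carbon in words, cyclopropyl in place of butyl on a saturated chain carbon bound to an oxygen on a saturated carbon. The same change reads pentyl to cyclopropylmethyl. Within the data shown here, no measured pair isolates this change, so the guide is thin. Among the measured compounds shown here, the only anchors are compound 1 at 7380 nM and compound 2 at 19800 nM as the measured span. In this assay I expect a small rise, not beyond the scatter. The estimated 1.5-fold higher number from compound 1 to compound 3 (0.17 log units; within the scatter) is a modest move toward more compound tolerated. Compound 3 is expected at 11000 nM with an estimated range from 5000 nM to 25000 nM for its measurement.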

Compound 3, half-maximal cytotoxic concentration: 77200 nM
Beside the measured number, compound 3's estimate is 7.0-fold (0.85 log units) below it; measured number above the stated range.
By their numbers in this assay, from the lowest: compound 1; then compound 2; then compound 3.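

In this assay, the change from pentyl to cyclopropylmethyl gives a 10-fold higher number from compound 1 to compound 3 (1.02 log units; beyond the scatter). The rest of the structure stays the same, and this pair isolates the chain on this oxygen. That shows the chain alone can strongly shift how much compound the cells tolerate, and the swap of an open butyl for a cyclopropyl ring at this place is far from a minor edit. Nothing measured alongside these numbers accounts for the rise.

A single step cannot tell whether the ring itself or the shorter chain goes with the higher number, and a straight butyl chain on the same oxygen of the same core would help separate the two. As far as these compounds go, how an amine or a carboxylic acid at the end of this chain would behave also stays open.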